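The source may hold more compounds than are shown below. What is called first, only, known or untested is meant among the compounds shown, and "the series" means these compounds.

In an ADME assay on HEK293 cells (Homo sapiens) for cytotoxicity, read by CellTiter-Glo and resazurin assay, with a stated time of 72 h (a lower number here means that less compound is needed, a higher number that more compound is needed for the effect), three compounds have been measured, and each gave only a limit of the assay rather than a number:

compound 1 `CC(C)N(Cc1cccc(OCCCCCC(=O)O)c1)C(=O)c1ccc(-c2ccc3[nH]ccc3c2)cc1`: > 26000 nM
compound 2 `CCOc1cccc(-c2ccc(C(=O)N(Cc3cccc(OCCCCCC(=O)O)c3)C(C)C)cc2)c1`: > 20800 nM
compound 3 `CCOC(=O)CCCCCOc1cccc(CN(C(=O)c2ccc(-c3ccc4[nH]ccc4c3)cc2)C(C)C)c1`: > 26000 nM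

Compound 2 differs from compound 1 by 3-ethoxyphenyl in place of 1H-indol-5-yl on an aromatic carbon. Because both values are limits, the step that the two limits leave unreadable from compound 1 to compound 2 cannot be read. The two cores differ in that compound 3 carries ethyl in place of hydrogen on an oxygen next to a carbonyl group, and the step that the two limits leave unreadable from compound 1 to compound 3 is equally unreadable. All three results sit at limits: the limit of > 26000 nM in this assay, at which 2 of the 3 values shown sit, and (the limit of > 20800 nM in this assay, at which 1 of the 3 values shown sits).

Compound 4 `CCOC(=O)CCCCCOc1cccc(CN(C(=O)c2ccc(-c3cccc(OCC)c3)cc2)C(C)C)c1` has not yet been measured. Going by the values given here, it differs from compound 3 by 3-ethoxyphenyl in place of 1H-indol-5-yl on an aromatic carbon, the same change as the one from compound 1 to compound 2, at the same place. For compound 4 the step that the limit leaves unreadable from compound 3 to compound 4 is expected, which rests on the unreadable step that the two limits leave unreadable from compound 1 to compound 2 and on compound 3 sitting at a limit, > 26000 nM. Compound 4 is therefore estimated at 30000 nM, most likely again reported only as a limit, with a range from 15000 nM to 100000 nM.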

Compound 4, half-maximal effective concentration: > 22300 nM
Compound 4: no number, only a limit; the forecaster's own chance of this, stated with the estimate: 85%; the middle value does not contradict the limit.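

In this assay compound 4 gives > 22300 nM, which is a limit and not a number. The steps to compound 4 from compound 2 and from compound 3 cannot be read. The compounds shown leave open whether 3-ethoxyphenyl in place of 1H-indol-5-yl, or ethyl in place of hydrogen on the acid oxygen, changes the amount of compound needed for the effect.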